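Swapping a Sulfanylethenyl Chain for Formyl on the Triazine Core

A few compounds are considered here, and "the series" means these few. Any claim that something is new, unique, unknown or untested is made for them only; others in the source may bear on it.

The measured compounds in a functional assay on Vero cells (Chlorocebus sabaeus) for cytotoxicity (a lower number here means a stronger inhibitor, a higher number a weaker inhibitor), are:
compound 1 `O=c1[nH]c(=O)n(C2C[C@@H](O)[C@@H](CO)O2)nc1/C=C/Br` with 355 ug/mL
compound 2 `CS/C=C/c1nn(C2C[C@@H](O)[C@@H](CO)O2)c(=O)[nH]c1=O` with 420 ug/mL
compound 3 `O=c1[nH]c(=O)n(C2C[C@@H](O)[C@@H](CO)O2)nc1-c1ccoc1` with 45 ug/mL

Compound 2 gives the highest number of the three in this assay. Its nearest neighbour is compound 1, and the step of a 1.2-fold higher number from compound 1 to compound 2 (0.07 log units; within the scatter) stays within the scatter, so the two cannot be ordered. Compound 3 sits furthest away, with the step of a 9.3-fold lower number from compound 2 to compound 3 (0.97 log units; beyond the scatter) going beyond the scatter.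

The unmeasured compound 4 `O=Cc1nn(C2C[C@@H](O)[C@@H](CO)O2)c(=O)[nH]c1=O` differs from compound 2 as follows: formyl in place of 2-(methylsulfanyl)ethenyl on an aromatic carbon.

Among the compounds with values here, no measured step exchanges the chain for a group of this small size. The step of a 1.2-fold higher number from compound 1 to compound 2 (0.07 log units; within the scatter) shows that changing the terminal atom of the chain left the number unchanged, while the step of a 9.3-fold lower number from compound 2 to compound 3 (0.97 log units; beyond the scatter) shows that replacing the whole chain by a ring lowered the number only modestly. Compound 4 keeps the shared core of compound 2 and loses the chain altogether, so a change of similar or smaller size is expected, leaning toward a lower number but possibly none beyond the scatter.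

Compound 4 is therefore estimated at 300 ug/mL in this assay, within a range of 100 ug/mL to 800 ug/mL, corresponding to an expected step of a 1.4-fold lower number from compound 2 to compound 4 (0.15 log units; within the scatter).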

Compound 4, concentration for 50% inhibition: 180 ug/mL
Compound 4: the middle estimate sits 1.7-fold (0.22 log units) above what was measured; the range from low to high includes it.
By their numbers in this assay, from the lowest: compound 3; then compounds 4, 1 and 2 (each within the scatter of the next, the first and the last beyond it).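

In this assay the exchange of 2-(methylsulfanyl)ethenyl for formyl on this aromatic carbon next to the ring nitrogen gives a 2.3-fold lower number from compound 2 to compound 4 (0.37 log units; beyond the scatter) and so shows that the number at this position can fall with no ring entering, which the earlier change at the end of the chain did not show. Against the bromo-bearing chain the same group gives a 2.0-fold lower number from compound 1 to compound 4 (0.29 log units; within the scatter) so compound 1 and compound 4 cannot be ordered, and formyl separates from only one of the two ethenyl compounds. Furan-3-yl still holds the lowest number, as a 4.0-fold higher number from compound 3 to compound 4 (0.60 log units; beyond the scatter) shows, so the smaller group does not reach the number of compound 3, whose steps to all three other compounds lie beyond the scatter.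

From the compounds shown here alone, whether that low number is particular to furan-3-yl, and where a phenyl ring, a thiophene ring, an amine or a carboxylic acid on this carbon would fall, stays open. Nothing given here accounts for any of these differences.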